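A few compounds are considered here, and "the series" means these few. Any claim that something is new, unique, unknown or untested is made for them only; others in the source may bear on it.

Measured so far in an ADME assay on MDBK cells (Bos taurus) for cytotoxicity, read by MTT assay, with a stated time of 96 h; a lower number here means that less compound is tolerated, a higher number that more compound is tolerated:
Compound 1 `CC(=O)Nc1ccc(-c2nc3cc(C(F)(F)F)ccc3[nH]2)cc1`: 50000 nM
Compound 2 `Fc1ccc(-c2nc3cc(C(F)(F)F)ccc3[nH]2)cc1`: 19000 nM

Within the data shown here, compound 2 stands lowest of these two numbers, and the only measured step leading to it is a 2.6-fold lower number from compound 1 to compound 2 (0.42 log units; beyond the scatter), fluoro in place of acetamido on an aromatic carbon. Compound 3 `O=C(CCl)Nc1ccc(-c2nc3cc(C(F)(F)F)ccc3[nH]2)cc1` differs from compound 2 as follows: ((chloromethyl)carbonyl)amino in place of fluoro on an aromatic carbon. Among the measured compounds shown here, the entering group closely resembles the acetamido that left in that single step, so the one relevant step points to a modest rise back toward compound 1, with a 1.8-fold higher number from compound 2 to compound 3 (0.27 log units; within the scatter) expected. The estimate for compound 3 is therefore 35000 nM, with a range from 12000 nM to 90000 nM.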

Compound 3, half-maximal cytotoxic concentration: 17000 nM
The estimate for compound 3 lay 2.1-fold (0.31 log units) above the measured number; the range from low to high includes it.
By their numbers in this assay, from the lowest: compounds 3 and 2 (each within the scatter of the next); then compound 1.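

In this assay, ((chloromethyl)carbonyl)amino in place of fluoro, para to a large group, gives a 1.1-fold lower number from compound 2 to compound 3 (0.05 log units; within the scatter) and so leaves the number where fluoro had it. Chloro in place of hydrogen on the chain carbon bound to the carbonyl carbon gives a 2.9-fold lower number from compound 1 to compound 3 (0.47 log units; beyond the scatter), which shows that an amide at this position does not by itself keep the higher number of compound 1. No evidence on the cause of either step is at hand. The compounds shown leave open whether bromo or a methoxy on that chain carbon would behave like chloro. They also leave open how a longer chain on the carbonyl or a free amine at this position would read.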